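Adding a Chloro Group: From Compound 3 to Compound 4

This account rests on a few compounds, and the source may have more. Where it says the series, first, only, none or still open, it means among the compounds named here.

Compound 1, `O=C(Nc1nc2ccccc2s1)c1cn(-c2ccccc2)nc1-c1ccc(F)cc1`, in a functional assay on U-87MG ATCC cells for cytotoxicity against U-87 MG (Homo sapiens), read by MTT assay, with a stated time of 72 h (a higher number here means a weaker inhibitor, a lower number a stronger inhibitor), gives 10700 nM.
Compound 2, `O=C(Nc1nc2ccc(Cl)cc2s1)c1cn(-c2ccccc2)nc1-c1ccc(F)cc1`, gives 6770 nM.
Compound 3, `O=C(Nc1nc2ccccc2s1)c1cn(-c2ccccc2)nc1-c1ccc(Cl)cc1`, gives 11500 nM.

Compound 3 sits in a tight group with the other two: its nearest neighbour is compound 1 and its furthest is compound 2, and neither gap exceeds the usual scatter, so none of the three can be told apart from the others on these numbers.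

Compound 4, `O=C(Nc1nc2ccc(Cl)cc2s1)c1cn(-c2ccccc2)nc1-c1ccc(Cl)cc1`, differs from compound 3 by one change: chloro in place of hydrogen on an aromatic carbon. Read one bond further out, the change is from 1,3-benzothiazol-2-yl to 6-chloro-1,3-benzothiazol-2-yl.

Going by the values given here, one measured step bears directly on this: a 1.6-fold lower number from compound 1 to compound 2 (0.20 log units; within the scatter), the same chloro-for-hydrogen exchange made on a compound that differs from compound 3 only in carrying fluoro where compound 3 carries chloro. That fluoro-to-chloro swap itself, a 1.1-fold higher number from compound 1 to compound 3 (0.03 log units; within the scatter), changed nothing beyond the scatter. For compound 4 the expected step is therefore a 1.6-fold lower number from compound 3 to compound 4 (0.20 log units; within the scatter), a small shift towards a lower number in line with what compound 2 showed, and one that may not clear the scatter. Compound 4 is estimated at 7200 nM, with a range from 3500 nM to 15000 nM.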

Compound 4, half-maximal inhibitory concentration: 5870 nM
Beside the measured number, compound 4's estimate is 1.2-fold (0.09 log units) above it; low and high end bracket the measured number.
By their numbers in this assay, from the lowest: compounds 4, 2, 1 and 3 (each within the scatter of the next).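

The chloro-for-hydrogen exchange that gives the 6-chloro-1,3-benzothiazol-2-yl group can now be read on two cores, and in this assay the new step, a 2.0-fold lower number from compound 3 to compound 4 (0.29 log units; within the scatter), agrees with the earlier one: the same change on two cores in this assay, a 1.6-fold lower number (0.20 log units; within the scatter) from compound 1 to compound 2 and a 2.0-fold lower number (0.29 log units; within the scatter) from compound 3 to compound 4, 1.2-fold (0.09 log units) apart, within the scatter of two such steps. The exchange of chloro for fluoro on an aromatic carbon can also now be read a second time, with a 1.2-fold lower number from compound 2 to compound 4 (0.06 log units; within the scatter) set against the earlier step: the same change on two cores in this assay, a 1.1-fold higher number (0.03 log units; within the scatter) from compound 1 to compound 3 and a 1.2-fold lower number (0.06 log units; within the scatter) from compound 2 to compound 4, 1.2-fold (0.09 log units) apart, within the scatter of two such steps. Taken together, the four compounds form a closed set in which neither exchange clears the scatter on either core, and each exchange reads the same on both cores.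

The compounds shown leave open whether an amine, a carboxylic acid or a longer chain in place of the chloro at this position would give a step beyond the scatter. They also leave open whether the chloro-for-hydrogen step would read the same on another aromatic carbon of that six-membered ring.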